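This account rests on a few compounds, and the source may have more. Where it says the series, first, only, none or still open, it means among the compounds named here.

Compound 1 `CCCC(Oc1ccc(-n2cc(C(=O)N(C)C)cn2)cc1)c1ccc(C(=O)NCCC(=O)O)cc1` gives 0.5 in a physicochemical assay for lipophilicity, using the shake flask method, at pH 7.4; a lower number here means a more polar compound, a higher number a more lipophilic compound. Compound 2 `CCCC(Nc1cnc(-n2cc(C(F)(F)F)cn2)nc1)c1ccc(C(=O)NCCC(=O)O)cc1` gives 1.3 in this assay. Of these two numbers compound 1 stands lowest, and compound 2 stands higher by a gap beyond the usual scatter. Compound 3 `CCCC(Oc1ccc(-n2cc3c(n2)CCCC3)cc1)c1ccc(C(=O)NCCC(=O)O)cc1` differs from compound 1 in one place: a group of 9 heavy atoms (7 carbon, 2 nitrogen; one five-membered aromatic ring with 2 hetero atoms, one six-membered non-aromatic ring of carbon only) in place of a group of 10 heavy atoms (6 carbon, 3 nitrogen, 1 oxygen; one five-membered aromatic ring with 2 hetero atoms), on an aromatic carbon. Going by the values given here, no measured pair shows this same change, so its effect is open. The step expected here is a number 1.50 log units higher from compound 1 to compound 3 (beyond the scatter), upward and beyond the scatter. For compound 3 the estimated distribution coefficient is 2, with a range from 1.3 to 2.7.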

Compound 3, distribution coefficient: 2.7
Beside the measured number, compound 3's estimate is 0.70 log units below it; measured number inside the range.
By their numbers in this assay, from the lowest: compound 1; then compound 2; then compound 3.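

At this position, on an aromatic carbon para to a large group, replacing 4-(dimethylcarbamoyl)-1H-pyrazol-1-yl with the group bearing a six-membered non-aromatic ring of carbon only gives a number 2.20 log units higher from compound 1 to compound 3 (beyond the scatter) in this assay, a large step. The position therefore responds strongly to the choice of group. Nothing available explains this step.

As far as these compounds go, the change removes the dimethylcarbamoyl group and adds the carbon-only ring in one move, so their separate shares remain open. A pyrazole carrying only a methyl or a nitrile could help to separate them.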